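This account rests on a few compounds, and the source may have more. Where it says the series, first, only, none or still open, it means among the compounds named here.

Measured so far:

Compound 1, `COc1ccc(-c2cc(/C=C/C(=O)c3ccc(OC)c(OC)c3)[nH]n2)cc1`, in a functional assay on 786-0 cells (Homo sapiens) for cytotoxicity, read by sulforhodamine B assay, with a stated time of 48 h, tested at 10 uM (on this read-out lower numbers stand for a stronger effect and higher numbers for a weaker effect at the one concentration tested), gives -89%.
Compound 2, `COc1cc(-c2cc(/C=C/C(=O)c3ccc(Cl)c(Cl)c3)[nH]n2)cc(OC)c1OC`, in this assay gives 50%.
Compound 3, `COc1ccc(-c2cc(/C=C/C(=O)c3ccc(N)cc3)[nH]n2)cc1OC`, in this assay gives -48%.

Among these three, compound 2 stands highest, which on this read-out means the weakest effect; its nearest neighbour is compound 3 and the furthest is compound 1, and both of those gaps lie beyond the scatter. Compound 4, `COc1ccc(C(=O)/C=C/c2cc(-c3cc(OC)c(OC)c(OC)c3)n[nH]2)cc1OC`, has not yet been measured. It differs from compound 2 in one place: 3,4-dimethoxyphenyl in place of 3,4-dichlorophenyl on a carbonyl carbon. The new ring is the same one that compound 1 carries on its carbonyl carbon, and compound 1 shows the strongest effect of the three. Within the data shown here, no step between measured compounds is known for this exact change, so the expectation rests on that resemblance alone. A large downward step is expected from compound 2, as a number 110 percentage points lower from compound 2 to compound 4 (beyond the scatter) in this assay. Compound 4 is therefore estimated at -60%, with a range from -100% to 20%.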

Compound 4, a percentage reported as activity, at one concentration (the size of the read-out at that concentration, not a potency): -88%
Estimate against measurement, compound 4: 28 percentage points above; the range from low to high includes it.
By their numbers in this assay, from the lowest: compounds 1 and 4 (each within the scatter of the next); then compound 3; then compound 2.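

In this assay, replacing 3,4-dichlorophenyl with 3,4-dimethoxyphenyl on a carbonyl carbon, with the rest of the molecule unchanged, gives a number 138 percentage points lower from compound 2 to compound 4 (beyond the scatter). Among these compounds, the earlier compounds differed from one another in more than one place, so this is the first direct sign that this position alone can turn a weak effect into a strong one. Nothing given here explains the size of this step.

Going by these compounds, this is a single change read against a single partner, so it remains open whether the same swap would have a similar effect on a different core. On these data alone, it is also open how a phenyl ring carrying one methoxy group, or a carboxylic acid on the ring, would behave at this position.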